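Working notes on compounds 1 to 4

The source may report more compounds than this note shows. Statements on the series, on what has been measured and on what is new or still open speak of the compounds shown alone.

compound 1 `Cn1c(/C=C2\SC(=O)N(CC(=O)N3CCOCC3)C2=O)nc2ccccc21` gives 41100 nM in a functional assay on DU-145 cells (Homo sapiens) for inhibition, read by MTT assay, with a stated time of 48 h; on this read-out higher numbers stand for weaker inhibition and lower numbers for stronger inhibition.
compound 2 `CC(C)n1c(/C=C2\SC(=O)N(CC(=O)N3CCOCC3)C2=O)nc2ccccc21` reaches only the assay limit > 50000 nM in this assay.
compound 3 `CC(C)n1c(/C=C2\SC(=O)N(CC(=O)N3CCCC3)C2=O)nc2ccccc21` reaches only the assay limit > 50000 nM in this assay.

Compound 4 `Cn1c(/C=C2\SC(=O)N(CC(=O)N3CCCC3)C2=O)nc2ccccc21` is not yet measured. It differs from compound 3 by methyl in place of isopropyl on an aromatic nitrogen. The same change between measured compounds is methyl in place of isopropyl on an aromatic nitrogen, which gave an at least 1.2-fold lower number from compound 2 to compound 1 (0.08 log units; that floor lies within the scatter). The two cores differ as pyrrolidin-1-yl in place of morpholin-4-yl on a carbonyl carbon; that step reads a step that the two limits leave unreadable from compound 2 to compound 3, and it cannot be sized because of the limit of > 50000 nM in this assay, at which 2 of the 3 values shown sit.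

For compound 4 the expected step is an at least 1.1-fold lower number from compound 3 to compound 4 (0.04 log units; that floor lies within the scatter). This rests on compound 1 sitting at 41100 nM in this assay. Compound 4 is estimated at 45000 nM in this assay, with an expected range from 22000 nM to 100000 nM.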

Compound 4, half-maximal inhibitory concentration: > 50000 nM
Compound 4: a limit, no number; the forecaster's own chance of this, stated with the estimate: 50%; middle value at least 1.1-fold (0.04 log units) away from the limit.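

In this assay compound 4 reaches only a limit, > 50000 nM, so methyl in place of isopropyl on an aromatic nitrogen gives no readable step with pyrrolidin-1-yl on the carbonyl carbon. For the compounds shown here, this step and the others between two limits cannot be read, because the values sit at the end of the measurable range: the limit of > 50000 nM in this assay, at which 3 of the 4 values shown sit. The one readable new step, for pyrrolidin-1-yl in place of morpholin-4-yl, is an at least 1.2-fold higher number from compound 1 to compound 4 (0.08 log units; that floor lies within the scatter), and nothing here shows either that the methyl change carries from one core to the other or that it fails to.

Open, going by these compounds, is whether a longer chain on the aromatic nitrogen would give a number rather than a limit. The same holds for an amine or a carboxylic acid in place of the groups on the carbonyl carbon.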